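The compounds below may be only part of what the source reports. "The series", "measured", "known", "first", "only" and "open" are said of these compounds alone.

Compound 1 `COc1ccc(C[C@H]2COC(=O)[C@@H]2Cc2ccc(OCC(=O)Nc3ccc(C)cc3)c(OC)c2)cc1OC`: 228000 nM
Compound 2 `CCN(CC)C(=O)COc1ccc(C[C@H]2C(=O)OC[C@@H]2Cc2ccc(OC)c(OC)c2)cc1OC`: 188000 nM

In an ADME assay on HeLa cells (Homo sapiens) for cytotoxicity, read by MTT assay (on this read-out lower numbers stand for stronger inhibition and higher numbers for weaker inhibition), compound 1 gives the highest of the two numbers, with compound 2 nearest, the step of a 1.2-fold lower number from compound 1 to compound 2 (0.08 log units; within the scatter) lying within the scatter. Compound 3 `COc1ccc(C[C@H]2COC(=O)[C@@H]2Cc2ccc(OCc3cn(-c4ccccc4)nn3)c(OC)c2)cc1OC` differs from compound 1 by 1-phenyl-1H-1,2,3-triazol-4-yl in place of (4-methylphenyl)carbamoyl on a saturated chain carbon bound to an oxygen on an aromatic ring. Among the measured compounds shown here, only that one measured step bears on this change, since it also reworks the carbamoyl end of the same chain, and it stayed within the scatter, so the step expected for compound 3 in this assay is a 1.1-fold lower number from compound 1 to compound 3 (0.06 log units; within the scatter). Compound 3 is therefore estimated at 200000 nM in this assay, within 70000 nM to 600000 nM.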

Compound 3, half-maximal inhibitory concentration: 124000 nM
For compound 3 the middle estimate is 1.6-fold (0.21 log units) above the measured one; the measured number falls inside the stated range.
By their numbers in this assay, from the lowest: compounds 3, 2 and 1 (each within the scatter of the next).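

In this assay, the 1-phenyl-1H-1,2,3-triazol-4-yl group removes the carbamoyl link altogether, yet the number stays within the scatter (a 1.8-fold lower number from compound 1 to compound 3 (0.26 log units; within the scatter)) and (a 1.5-fold lower number from compound 2 to compound 3 (0.18 log units; within the scatter)). The three end groups on this saturated chain carbon bound to an oxygen on an aromatic ring thus give numbers within the scatter of one another, whether the end group is an amide or a triazole. Nothing available explains this result. Going by these compounds, whether a carboxylic acid or a primary amine at this place would move the number beyond the scatter remains open.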